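This account rests on a few compounds, and the source may have more. Where it says the series, first, only, none or still open, it means among the compounds named here.

The three measured compounds share one core and differ only in the chain on the sulfur: compound 1 `CC1=C(SCCCO)C(=O)c2ccccc2C1=O`, compound 2 `CC1=C(SCCCCO)C(=O)c2ccccc2C1=O` and compound 3 `CC1=C(SC(C)C(C)O)C(=O)c2ccccc2C1=O`. In a functional assay on A549 cells (Homo sapiens) for inhibition (on this read-out lower numbers stand for stronger inhibition and higher numbers for weaker inhibition), compound 1 gives only a limit of the assay, > 10000 nM. Compound 2 likewise gives only a limit in this assay, > 10000 nM. Among the compounds with values here, compound 3 also gives only a limit in this assay, > 10000 nM, so compound 3 stands where every value so far sits, at the limit of > 10000 nM in this assay, at which 3 of the 3 values shown sit. The steps between them, a step that the two limits leave unreadable from compound 1 to compound 2, a step that the two limits leave unreadable from compound 1 to compound 3 and a step that the two limits leave unreadable from compound 2 to compound 3, are therefore all of unreadable size, and no direction can be drawn from any of them.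

Compound 4 `CC1=C(SCC(C)O)C(=O)c2ccccc2C1=O` has not yet been measured in this assay. It differs from compound 3 by hydrogen in place of methyl on a saturated chain carbon bound to a saturated chain carbon and a sulfur. Within the data shown here, since none of the measured steps has a readable size, nothing in the data argues for a change beyond the scatter, and the expected step is a step that the limit leaves unreadable from compound 3 to compound 4. Compound 4 is therefore estimated to give about 20000 nM in this assay, in a range from 5000 nM to 100000 nM, most probably again reported only as a limit.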

Compound 4, half-maximal inhibitory concentration: 4740 nM
Estimate against measurement, compound 4: 4.2-fold (0.63 log units) above; measured number below the stated range.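

In this assay, compound 4 with its 2-hydroxypropyl chain on the sulfur is the only compound shown that gives a number rather than a limit, while the others all stop at the same limit: the limit of > 10000 nM in this assay, at which 3 of the 4 values shown sit. Hydrogen in place of methyl on a saturated chain carbon bound to a saturated chain carbon and a sulfur gives an at least 2.1-fold lower number from compound 3 to compound 4 (0.32 log units; beyond the scatter), so a change at this carbon can now be read. The chain itself also matters, with 1-hydroxyethyl in place of 3-hydroxypropyl on a saturated chain carbon bound to a sulfur giving an at least 2.1-fold lower number from compound 2 to compound 4 (0.32 log units; beyond the scatter), and 1-hydroxyethyl in place of 2-hydroxyethyl at that place giving an at least 2.1-fold lower number from compound 1 to compound 4 (0.32 log units; beyond the scatter).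

From the compounds shown here alone, the full size of these steps stays open, and the steps among compound 1, compound 2 and compound 3 cannot be read. Also open, going by these compounds, is whether an amine or a carboxylic acid in place of the hydroxy on the 2-hydroxypropyl chain would hold, lower or raise the number of compound 4.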